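Swapping Chloro for Trifluoromethyl on a Cathepsin S Inhibitor

The source may hold more compounds than are shown below. What is called first, only, known or untested is meant among the compounds shown, and "the series" means these compounds.

Of the compounds shown here, three sharing one core have been tested in an assay on isolated protein for inhibition of cathepsin S (Homo sapiens), read by fluorescence, with a stated time of 20 min; on this read-out lower numbers stand for stronger inhibition and higher numbers for weaker inhibition. Compound 1 `N#CCNC(=O)[C@@H]1CC(F)(F)C[C@H]1C(=O)N1CCOCC1` gives 830 nM. Compound 2 `N#CCNC(=O)[C@@H]1C[C@@H](S(=O)(=O)CC2CC2)C[C@H]1C(=O)N1CCOCC1` gives 230 nM. Compound 3 `N#CCNC(=O)[C@@H]1C[C@@H](S(=O)(=O)c2ccccc2Cl)C[C@H]1C(=O)N1CCOCC1` gives 0.5 nM, the lowest of the three numbers; the step of a 460-fold lower number from compound 2 to compound 3 (2.66 log units; beyond the scatter) is large, and the gap from compound 3 back to compound 1 is wider still. Compound 4 `N#CCNC(=O)[C@@H]1C[C@@H](S(=O)(=O)c2ccccc2C(F)(F)F)C[C@H]1C(=O)N1CCOCC1` has not yet been measured in this assay. It differs from compound 3 in one place: trifluoromethyl in place of chloro on an aromatic carbon. Within the data shown here, the only measured step, from compound 2 to compound 3, concerns a different part of the molecule, the group carried by the sulfonyl sulfur, and was large; no measured step here speaks to exchanging one substituent for another on the aromatic ring itself. Among the measured compounds shown here, with no direct precedent, the expected step of a 1.4-fold higher number from compound 3 to compound 4 (0.15 log units; within the scatter) is small and within the usual scatter, in either direction. Compound 4 is estimated at 0.7 nM, with a range from 0.2 nM to 3 nM.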

Compound 4, half-maximal inhibitory concentration: 0.9 nM
Compound 4: the middle estimate sits 1.3-fold (0.11 log units) below what was measured; low and high end bracket the measured number.
By their numbers in this assay, from the lowest: compounds 3 and 4 (each within the scatter of the next); then compound 2; then compound 1.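

In this assay, placing trifluoromethyl instead of chloro on this aromatic carbon, ortho to a large group, gives a 1.8-fold higher number from compound 3 to compound 4 (0.26 log units; within the scatter), so the two compounds cannot be told apart even though trifluoromethyl carries more heavy atoms. The large difference from the cyclopropylmethyl compound also appears with this second substituent, as a 260-fold lower number from compound 2 to compound 4 (2.41 log units; beyond the scatter) shows, so among these compounds it is not tied to chloro alone. No measurement available here bears on why the two substituents read alike.

The compounds shown leave open whether a substituent of a different kind on the same aromatic carbon, such as an amine or a carboxylic acid, would give a similar number. Going by these compounds, it also remains open how a plain hydrogen or a longer chain at this place would compare.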